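A few compounds are considered here, and "the series" means these few. Any claim that something is new, unique, unknown or untested is made for them only; others in the source may bear on it.

In a functional assay on HCT-116 cells (Homo sapiens) for cytotoxicity, with a stated time of 3 days (on this read-out higher numbers stand for weaker inhibition and lower numbers for stronger inhibition), compound 1 (`C#Cc1nc(/C=C/C(=O)Nc2ccc(Cl)cc2)cs1`) gives 23200 nM. Compound 3 (`C#CCNC(=O)c1csc(C#Cc2ccccc2)n1`) reads > 40000 nM, which is a limit and not a number. Compound 2 (`CC#Cc1nc(C(=O)OCC)cs1`) reads > 40000 nM, also a limit and not a number. Compound 2 therefore stands at the limit of > 40000 nM in this assay, at which 2 of the 3 values shown sit, with no exact value to its name.

Compound 4 (`C#Cc1nc(C(=O)OCC)cs1`) follows from compound 2 by hydrogen in place of methyl on a triple-bonded carbon. Within the data shown here, no measured pair isolates this change. Compound 1, which also bears ethynyl, reads 23200 nM, so a measurable value cannot be ruled out. In this assay the expected a number no higher from compound 2 to compound 4 (the limit leaves the size open) stays within the scatter, and a further limit reading is likely. For compound 4 the estimate is 40000 nM, with an expected range of 18000 nM to 80000 nM.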

Compound 4, half-maximal inhibitory concentration: > 40000 nM
Compound 4: a limit, no number; the forecaster's own chance of this, stated with the estimate: 60%; the middle value lies on the limit itself.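

No step can be read from compound 2 to compound 4, since both stand at a limit and not a number: the limit of > 40000 nM in this assay, at which 3 of the 4 values shown sit.

The compounds shown leave open how prop-1-yn-1-yl and ethynyl compare on the shared core.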